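The compounds below may be only part of what the source reports. "The series", "measured", "known", "first", "only" and "open" are said of these compounds alone.

Measured compounds:
compound 1 `Nc1nnc(SC[C@H]2O[C@@H](OCc3noc(-c4ccc(Cl)cc4)n3)[C@@H]3OC4(CCCC4)O[C@@H]32)s1`, 15000 nM
compound 2 `CC1(C)O[C@H]2[C@H](OCc3noc(-c4ccc([N+](=O)[O-])cc4)n3)O[C@H](CO)[C@H]2O1`, 99000 nM
compound 3 `COc1cc(-c2nc(CO[C@@H]3O[C@H](CSc4nnc(N)s4)[C@H]4OC5(CCCC5)O[C@@H]34)no2)cc(OC)c1OC`, 36000 nM

In a functional assay on A549 cells (Homo sapiens) for antiproliferative activity, read by sulforhodamine B assay, with a stated time of 48 h (on this read-out higher numbers stand for weaker inhibition of growth and lower numbers for stronger inhibition of growth), compound 2 gives the highest of the three numbers; compound 3 sits nearest to it and compound 1 furthest, both beyond the scatter. The measured step of a 2.4-fold higher number from compound 1 to compound 3 (0.38 log units; beyond the scatter) concerns the aryl group on the shared core and does not touch the change considered here.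

Compound 4 `CC1(C)O[C@H]2[C@H](OCc3noc(-c4ccc([N+](=O)[O-])cc4)n3)O[C@H](CSc3nnc(N)s3)[C@H]2O1` differs from compound 2 by (5-amino-1,3,4-thiadiazol-2-yl)sulfanyl in place of hydroxy on a saturated chain carbon bound to a saturated ring carbon. Within the data shown here, no measured pair isolates this change: compounds 1 and 3 carry the same (5-amino-1,3,4-thiadiazol-2-yl)sulfanyl group and give lower numbers than compound 2, but they also differ from it at the ketal and at the aryl group, so their values only hint at the direction. On that basis a lower number than compound 2 is expected for compound 4, with wide uncertainty.

The expected step is a 2.8-fold lower number from compound 2 to compound 4 (0.45 log units; beyond the scatter). Compound 4 is estimated at 35000 nM, within a range from 10000 nM to 120000 nM.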

Compound 4, concentration for 50% growth inhibition: > 100000 nM
Compound 4: only a limit was reported; the forecaster's own chance of this, stated with the estimate: 15%; middle value at least 2.8-fold (0.45 log units) away from the limit.
By their numbers in this assay, from the lowest: compound 1; then compound 3; then compound 2. At a limit, above all of these: compound 4.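

Compound 4 is reported only as a limit > 100000 nM in this assay and not as a number. Here, (5-amino-1,3,4-thiadiazol-2-yl)sulfanyl in place of hydroxy on a saturated chain carbon bound to a saturated ring carbon therefore brings no readable gain in growth inhibition, with a number no lower from compound 2 to compound 4 (the limit leaves the size open) and so this group does not by itself secure a lower number at this position. The size of this step cannot be read, because the result rests on a limit: the limit of > 100000 nM in this assay, at which 1 of the 4 values shown sits.

Going by these compounds, how far compound 4 lies from compound 2 remains open, as does whether the ketal or the aryl group decides how this group behaves. Also open, on these data alone, is how an amine or a carboxylic acid would compare with hydroxy at this position on the same core.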